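Swapping Iodine for Fluorine in Two Calpain Inhibitor Scaffolds

This account rests on a few compounds, and the source may have more. Where it says the series, first, only, none or still open, it means among the compounds named here.

Three compounds have been measured in an assay on isolated protein for inhibition of Calpain-1 catalytic subunit (Sus scrofa), read by FRET; a higher number here means a weaker inhibitor, a lower number a stronger inhibitor:

Compound 1, `O=C(O)/C(S)=C/c1c[nH]c2ccc(F)cc12`, gives 800 nM.
Compound 2, `O=C(O)/C(S)=C/c1c[nH]c2ccc(I)cc12`, gives 100 nM.
Compound 3, `O=C(O)/C(S)=C/c1ccccc1I`, gives 29600 nM.

Compound 1 and compound 2 share one core and differ in a single spot: fluoro in place of iodo on an aromatic carbon. This single swap gave an 8.0-fold higher number from compound 2 to compound 1 (0.90 log units; beyond the scatter), so the fluoro compound is the weaker inhibitor of the pair.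

Compound 3 carries a different core; how the two cores differ is not broken down here. Its number in this assay stands far above that of compound 1 and further still above that of compound 2, making it the weakest of the three measured compounds.

Compound 4, `O=C(O)/C(S)=C/c1ccccc1F`, is not yet measured. It relates to compound 3 in the same way that compound 1 relates to compound 2: fluoro in place of iodo on an aromatic carbon. The surroundings are not identical, though. In compound 2 the iodo sits on a ring that is part of a fused or bridged system of two rings, meta to a fused ring and para to a fused ring; in compound 3 it sits on a six-membered aromatic ring of carbon only, ortho to a group of 6 heavy atoms. The change is therefore the same kind of change, not the same change.

Within the data shown here, the expectation for compound 4 is a step of a 3.0-fold higher number from compound 3 to compound 4 (0.48 log units; beyond the scatter) in this assay, in the same direction as an 8.0-fold higher number from compound 2 to compound 1 (0.90 log units; beyond the scatter) but judged smaller, since the place of the swap is not the same and only one earlier example exists. Compound 4 is thus estimated at 90000 nM, most likely between 25000 nM and 300000 nM, with a real chance that the assay reports only a limit.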

Compound 4, half-maximal inhibitory concentration: 21900 nM
Beside the measured number, compound 4's estimate is 4.1-fold (0.61 log units) above it; measured number outside the range, below it.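

In this assay, putting fluoro in place of iodo gives a 1.4-fold lower number from compound 3 to compound 4 (0.13 log units; within the scatter), so on the core of compound 3 this swap produces no change that can be told apart from ordinary repeat variation. On the core of compound 1 the same kind of swap did produce a clear change, and the two results do not agree: the same change on two cores in this assay, an 8.0-fold higher number (0.90 log units; beyond the scatter) from compound 2 to compound 1 and a 1.4-fold lower number (0.13 log units; within the scatter) from compound 3 to compound 4, 11-fold (1.03 log units) apart, beyond the scatter of two such steps. Among these compounds, this shows that, in this series, the size of the step seen on one core cannot simply be carried over to the other, but it does not show why the two differ: the evidence is only two pairs of compounds, the swap sits in a different place on each core, and nothing here separates the influence of the core from that of the place.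

Going by these compounds, what stays open is whether other halogens, such as chloro or bromo, or a small carbon group such as methyl, in the same places would give a clear step on the core of compound 1 and none on the core of compound 3. On these data alone, it is also open whether the contrast between the two cores would hold if an ester or an amide stood in place of the carboxylic acid that all four compounds share.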